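Moving the Nitro Group: What to Expect for Compound 3

The source may hold more compounds than are shown below. What is called first, only, known or untested is meant among the compounds shown, and "the series" means these compounds.

Measured so far:
compound 1 `Cc1ccc(C2C(C#N)=C(N)N(c3ccc(S(N)(=O)=O)cc3)C3=C2CCCC3)cc1` gives 80% in a functional assay on Ehrlich cells (Mus musculus) for cytotoxicity, read by trypan blue exclusion, with a stated time of 2 h, tested at 50 ug/mL; on this read-out lower numbers stand for a weaker effect and higher numbers for a stronger effect at the one concentration tested
compound 2 `N#CC1=C(N)N(c2ccc(S(N)(=O)=O)cc2)C2=C(CCCC2)C1c1cccc([N+](=O)[O-])c1` gives 2% in this assay

Going by the values given here, compound 2 has the lower of the two numbers; its nearest neighbour is compound 1, and the one measured step was a number 78 percentage points lower from compound 1 to compound 2 (beyond the scatter), where a 3-nitrophenyl replaced a 4-methylphenyl. Compound 3 `N#CC1=C(N)N(c2ccc(S(N)(=O)=O)cc2)C2=C(CCCC2)C1c1ccc([N+](=O)[O-])cc1` differs from compound 2 only in 4-nitrophenyl in place of 3-nitrophenyl on a saturated ring carbon. Among the compounds with values here, no measured step moves a nitro group from one position to another, so none bears directly on this change; the expected step is a number 6 percentage points higher from compound 2 to compound 3 (within the scatter), none beyond the scatter. Compound 3 is therefore estimated at 8%, within 0% to 35%.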

Compound 3, a percentage reported as activity, at one concentration (the size of the read-out at that concentration, not a potency): 10%
Compound 3: the middle estimate sits 2 percentage points below what was measured, within the range that was stated.
By their numbers in this assay, from the lowest: compounds 2 and 3 (each within the scatter of the next); then compound 1.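

In this assay, shifting the nitro group gives a number 8 percentage points higher from compound 2 to compound 3 (within the scatter) and so does not separate 3-nitrophenyl from 4-nitrophenyl on this saturated ring carbon. With the substituent named at the same phenyl position, nitro in place of methyl gives a number 70 percentage points lower from compound 1 to compound 3 (beyond the scatter), so the large drop seen earlier is not tied to 3-nitrophenyl alone. Nothing available explains this drop. Still open, as far as these compounds go, is where other groups on the phenyl ring, such as an amine, a carboxylic acid or an ethyl group, would fall. Whether any of them would retain the high number of compound 1 cannot be told from these three compounds.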